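Fluoro for chloro: the next step from compound 2

The source may hold more compounds than are shown below. What is called first, only, known or untested is meant among the compounds shown, and "the series" means these compounds.

Going by the values given here, compound 2 `CN1CCC(NC(=O)c2ccc(Nc3ncc(Cl)c(NC4CCCC4)n3)cc2)CC1` gives 1800 nM in a functional assay on A549 cells (Homo sapiens) for cytotoxicity, read by MTT assay, with a stated time of 48 h (on this read-out lower numbers stand for stronger inhibition and higher numbers for weaker inhibition), the lowest of the three numbers so far. Compound 1 `COc1cc(C(=O)NC2CCN(C)CC2)ccc1Nc1ncc(Br)c(NC2CCCC2)n1` gives 2500 nM in this assay, a gap to compound 2 that lies within the scatter. Compound 3 `COc1cc(C(=O)NC2CCN(C)CC2)ccc1Nc1ncc(Cl)c(NC2CCCC2)n1` gives 5300 nM in this assay; the step of a 2.9-fold higher number from compound 2 to compound 3 (0.47 log units; beyond the scatter) and the step of a 2.1-fold higher number from compound 1 to compound 3 (0.33 log units; beyond the scatter) are both modest but beyond the scatter. Compound 4 `CN1CCC(NC(=O)c2ccc(Nc3ncc(F)c(NC4CCCC4)n3)cc2)CC1` differs from compound 2 by fluoro in place of chloro on an aromatic carbon. Only the exchange of the halogen on this aromatic carbon bears on it, and that step was a 2.1-fold higher number from compound 1 to compound 3 (0.33 log units; beyond the scatter). A modest rise in the number is therefore expected for compound 4, about a 2.0-fold higher number from compound 2 to compound 4 (0.30 log units; within the scatter). Compound 4 is estimated at 3600 nM, with a range from 1800 nM to 7500 nM.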

Compound 4, half-maximal inhibitory concentration: 10300 nM
Compound 4: middle estimate off by 2.9-fold (0.46 log units), on the low side, outside the stated range (above it).
By their numbers in this assay, from the lowest: compounds 2 and 1 (each within the scatter of the next); then compounds 3 and 4 (each within the scatter of the next).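

Fluoro in place of chloro gives a 5.7-fold higher number from compound 2 to compound 4 (0.76 log units; beyond the scatter) in this assay, so the halogen on this aromatic carbon, ortho to the cyclopentylamino group, also moves the number in compounds without the methoxy group. Both halogen exchanges shown, this one and a 2.1-fold higher number from compound 1 to compound 3 (0.33 log units; beyond the scatter), raise the number, and no pair shown goes against that. Nothing available explains this rise. The compounds shown leave open how a nitrile or a methyl group on this carbon would read. On these data alone, whether fluoro gives a similar rise alongside the methoxy group also remains open.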